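A phenyl swap on a compound without a number

The compounds below may be only part of what the source reports. "The series", "measured", "known", "first", "only" and "open" are said of these compounds alone.

Among the compounds with values here, three compounds sharing one core went into a functional assay on HEL cells (Homo sapiens) for cytotoxicity (a lower number here means that less compound is tolerated, a higher number that more compound is tolerated), and only one returned a number. Compound 1 (`CO[C@@H]1[C@@H](OC)[C@H](c2ccccc2)O[C@@H]2CO[C@@H](C3CCCCC3)O[C@@H]12`) gives 28 ug/mL as its half-maximal cytotoxic concentration. Compound 3 (`CO[C@@H]1[C@@H](OC)[C@H](c2ccccc2)O[C@@H]2CO[C@@H](c3cccc(Cl)c3)O[C@@H]12`) has only the entry "not determined" (no result reported) and offers no comparison. Compound 2 (`CO[C@@H]1[C@@H](OC)[C@H](c2ccccc2)O[C@@H]2CO[C@@H](c3ccc([N+](=O)[O-])cc3)O[C@@H]12`) stands in the same place: its entry reads "not determined" (no result reported) and so it cannot be ranked against compound 1.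

The step from there is one structural change (phenyl in place of nitro on an aromatic carbon): phenyl in place of nitro on an aromatic carbon, para to a large group. It yields compound 4 (`CO[C@@H]1[C@@H](OC)[C@H](c2ccccc2)O[C@@H]2CO[C@@H](c3ccc(-c4ccccc4)cc3)O[C@@H]12`), which is still unmeasured. Within the data shown here, no pair of measured compounds shows what a single change does in this assay here, so the size of this step has no direct precedent. Compound 2 offers no starting number, which leaves compound 1 at 28 ug/mL as the only anchor. The expectation is therefore no step beyond the usual scatter from that anchor, in neither direction. One number is thin support, so the range is kept wide. Compound 4 is expected near 28 ug/mL on this read-out, with 7 ug/mL to 100 ug/mL as the estimated range.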

Compound 4, half-maximal cytotoxic concentration: > 50 ug/mL
Compound 4: only a limit was reported; the forecaster's own chance of this, stated with the estimate: 30%; middle value at least 1.7-fold (0.25 log units) from the limit.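

Compound 4 gives > 50 ug/mL in this assay, which is a limit of the assay and not a number. Within the data shown here, compound 2 has no reported result, and no step from it to compound 4 can be read. As far as these compounds go, what putting phenyl in place of nitro does to cytotoxicity stays open, as does the actual half-maximal concentration of compound 4.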